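This account rests on a few compounds, and the source may have more. Where it says the series, first, only, none or still open, it means among the compounds named here.

Working notes on the series in a functional assay on the whole organism (Tail, strain ICR) with Mus musculus as the target, in the tail flick test, with a stated time of 90 min, at a dose of 25 umol/kg by the oral route; a lower number here means a weaker effect, a higher number a stronger effect of the compound at the dose given.

Compound 1 `C[C@H](NC(=O)CN(c1nc(Cl)nc2[nH]cnc12)C1CC1)C(=O)OCc1ccccc1` gives 44.2% in this assay. Among the compounds with values here, compound 2 `O=C(CN(c1nc(Cl)nc2[nH]cnc12)C1CC1)N[C@@H](CC(=O)OCc1ccccc1)C(=O)OCc1ccccc1` gives 15.6% in this assay, which places compound 2 lowest of the two numbers so far; its nearest neighbour is compound 1. Within the data shown here, the one measured step, a number 28.6 percentage points lower from compound 1 to compound 2 (beyond the scatter), is the only comparison available: benzyloxycarbonyl in place of hydrogen on a saturated chain carbon, two bonds along the chain from an amide-type nitrogen and a carbonyl carbon.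

Compound 3 `O=C(CN(c1nc(Cl)nc2[nH]cnc12)C1CC1)N[C@@H](CCC(=O)OCc1ccccc1)C(=O)OCc1ccccc1` has not been measured in this assay. The change from compound 2 is (benzyloxycarbonyl)methyl in place of benzyloxycarbonyl on a saturated chain carbon, two bonds along the chain from an amide-type nitrogen and a carbonyl carbon. The step from compound 1 to compound 2 bears on it only loosely, since it touched the same saturated chain carbon but added a group where none stood, whereas here an existing group is lengthened by one chain carbon. Among the measured compounds shown here, on that basis the expected step of a number 0.4 percentage points higher from compound 2 to compound 3 (within the scatter) is one that stays within the scatter, with no direction claimed, because the sole reference a number 28.6 percentage points lower from compound 1 to compound 2 (beyond the scatter) does not address the length of the side chain. Compound 3 is therefore estimated at 16%, with a range from 4% to 36%.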

Compound 3, a percentage reported as activity, at one dose (the size of the read-out at that dose, not a potency): 50%
Compound 3: the middle estimate sits 34 percentage points below what was measured; measured number above the stated range.
By their numbers in this assay, from the lowest: compound 2; then compounds 1 and 3 (each within the scatter of the next).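

At this saturated chain carbon, two bonds along the chain from an amide-type nitrogen and a carbonyl carbon, the read-out in this assay depends on more than whether an ester-bearing group is present: exchanging benzyloxycarbonyl for (benzyloxycarbonyl)methyl gives a number 34.4 percentage points higher from compound 2 to compound 3 (beyond the scatter) for that one change. A substituent at this carbon does not by itself bring the number down, since (benzyloxycarbonyl)methyl in place of hydrogen gives a number 5.8 percentage points higher from compound 1 to compound 3 (within the scatter) and leaves compound 1 and compound 3 indistinguishable, so among these three compounds the low number belongs to benzyloxycarbonyl alone. Nothing measured on these compounds accounts for the difference between the two substituents.

As far as these compounds go, whether the number holds with a longer chain carrying the same benzyl ester, or falls away again, remains open, as three compounds cannot define a trend in chain length. Also open, from the compounds shown here alone, is whether the benzyl ester matters at all, which a carboxylic acid or a primary amide at the end of the (benzyloxycarbonyl)methyl chain would address.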